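This account rests on a few compounds, and the source may have more. Where it says the series, first, only, none or still open, it means among the compounds named here.

Measured compounds:
- compound 1, `Fc1cccc(-c2nc(Nc3ccccc3)c3ccccc3n2)c1`
- compound 2, `COc1ccc(Nc2nc(-c3cccc(F)c3)nc3ccc(F)cc23)cc1`
- compound 3, `Fc1cccc(Nc2nc(-c3cccc(F)c3)nc3ccc(F)cc23)c1`

In a functional assay on U-937 cells (Homo sapiens) for cytotoxicity, read by MTT assay, with a stated time of 48 h (on this read-out lower numbers stand for stronger inhibition and higher numbers for weaker inhibition), compound 1 reaches only the limit of the measurement, > 50000 nM. In this assay compound 2 gives 41100 nM. In this assay compound 3 gives 42300 nM. These two numbers sit together: the step of a 1.0-fold higher number from compound 2 to compound 3 (0.01 log units; within the scatter) is within the scatter, so compound 3 and compound 2 cannot be told apart on this read-out. The third value, that of compound 1, is a limit and not a number, so it offers no comparison.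

Compound 4, `Fc1cccc(-c2nc(Nc3ccc(Br)cc3)c3cc(F)ccc3n2)c1`, differs from compound 3 in one place: 4-bromophenyl in place of 3-fluorophenyl on a nitrogen on an aromatic ring. Among the measured compounds shown here, only one measured step touches this position, a 1.0-fold higher number from compound 2 to compound 3 (0.01 log units; within the scatter), and it exchanged one ring on that nitrogen for another without moving the number beyond the scatter. The change to compound 4 is again an exchange of one such ring for another, so no step beyond the scatter is expected in this assay, in either direction. The expected step is a 1.0-fold lower number from compound 3 to compound 4 (0.00 log units; within the scatter). Compound 4 is estimated at 42000 nM, with a range from 15000 nM to 120000 nM, and with a real chance that the measurement again ends at a limit.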

Compound 4, half-maximal inhibitory concentration: > 50000 nM
Compound 4: a limit, no number; the forecaster's own chance of this, stated with the estimate: 40%; middle value at least 1.1-fold (0.07 log units) from the limit.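

In this assay compound 4 gives > 50000 nM, and this is a limit, not a number. The steps can therefore be read only as floors: an at least 1.1-fold higher number from compound 3 to compound 4 (0.07 log units; that floor lies within the scatter), and an at least 1.2-fold higher number from compound 2 to compound 4 (0.08 log units; that floor lies within the scatter), so the true size of each change could be negligible or much larger, and neither step shows a real difference on its own. What is new is that, among the three rings on this nitrogen on the core shared by compound 2, compound 3 and compound 4, 4-bromophenyl is the only one that gives no number, whereas the earlier exchange left two numbers that could not be told apart: the limit of > 50000 nM in this assay, at which 2 of the 4 values shown sit.

The compounds shown leave open whether any group on this nitrogen can move the number beyond the scatter, and in which direction, since no readable step at this position does so. They also leave open whether the bromine or its place on the ring matters, which a 3-bromophenyl group could help to separate, and how a ring carrying a carboxylic acid or an amine would behave here.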